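This account rests on a few compounds, and the source may have more. Where it says the series, first, only, none or still open, it means among the compounds named here.

Three compounds built on one shared core were tested in a functional assay on MCF7 cells (Homo sapiens) for cytotoxicity, read by MTT assay, with a stated time of 72 h; on this read-out higher numbers stand for weaker inhibition and lower numbers for stronger inhibition. Compound 1 `CCOC(=O)c1c(C)oc2ncnc(Nc3ccccc3)c12` gives 851000 nM, compound 2 `Cc1oc2ncnc(Nc3cccc(Cl)c3)c2c1C(=O)NC(C)C` gives 191000 nM, and compound 3 `Cc1oc2ncnc(Nc3cccc(Br)c3)c2c1C(=O)NCCO` gives 22000 nM. Compound 3 therefore shows the lowest number of the three, meaning the strongest inhibition, with compound 2 nearest and compound 1 furthest; both gaps lie beyond the scatter. Compound 4 `Cc1oc2ncnc(Nc3cccc(Br)c3)c2c1CO` is not yet measured and differs from compound 3 in one place: hydroxymethyl in place of (2-hydroxyethyl)carbamoyl on an aromatic carbon. Within the data shown here, no two measured compounds differ in only one place, so no measured step guides this change. A modest weakening, a little beyond the scatter, is expected, as a 2.3-fold higher number from compound 3 to compound 4 (0.36 log units; beyond the scatter). Compound 4 is expected to give about 50000 nM, within a range from 10000 nM to 250000 nM.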

Compound 4, half-maximal inhibitory concentration: 11000 nM
For compound 4 the middle estimate is 4.5-fold (0.66 log units) above the measured one, and the stated range covers the measured number.
By their numbers in this assay, from the lowest: compounds 4 and 3 (each within the scatter of the next); then compound 2; then compound 1.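

In this assay, among these compounds, the change to hydroxymethyl in place of (2-hydroxyethyl)carbamoyl gives a 2.0-fold lower number from compound 3 to compound 4 (0.30 log units; within the scatter) and offers the first comparison here of compounds that differ in one place. On this aromatic carbon, a group of 6 heavy atoms can thus be replaced by one of 2 heavy atoms, without any difference beyond the usual scatter. Nothing available explains this tolerance. Going by these compounds, whether a carboxylic acid, an aminomethyl group or a longer chain at this carbon would also leave the number within the scatter remains open.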